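The source may hold more compounds than are shown below. What is called first, only, known or untested is meant among the compounds shown, and "the series" means these compounds.

In an ADME assay on HEK293 cells (Homo sapiens) for inhibition, read by MTT assay, with a stated time of 96 h (a higher number here means a weaker inhibitor of growth, a lower number a stronger inhibitor of growth), compound 1 (`O=C(OCc1ccccc1)SCCCCCCNC(=O)c1cc(-c2ccncc2)n[nH]1`) gives 19700 nM as its measured concentration. Compound 2 (`CC(C)C(=O)SCCCCCCNC(=O)c1cc(-c2ccncc2)n[nH]1`) stands at > 50000 nM and this is a limit of the assay, not a number. Compound 3 (`C=CCOC(=O)SCCCCCCNC(=O)c1cc(-c2ccncc2)n[nH]1`) differs from compound 2 by allyloxy in place of isopropyl on a carbonyl carbon and so carries allyloxy in place of isopropyl on a carbonyl carbon whose other neighbour is sulfur. For the measured compounds named here, the one measured step that bears on this is an at least 2.5-fold higher number from compound 1 to compound 2 (0.40 log units; beyond the scatter) with isopropyl in place of benzyloxy at that same place, and its size is only a minimum. Read in reverse, that step from compound 1 points to a modest move towards a lower number in this assay for compound 3, though a second limit reading remains quite possible. The expected step is an at least 1.5-fold lower number from compound 2 to compound 3 (0.18 log units; that floor lies within the scatter) on this estimate. For compound 3 the estimated value is 33000 nM with an expected range of 14000 nM to 60000 nM in this assay.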

Compound 3, concentration for 50% growth inhibition: 27500 nM
The estimate for compound 3 lay 1.2-fold (0.08 log units) above the measured number; the range from low to high includes it.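

In this assay, allyloxy in place of isopropyl on a carbonyl carbon whose other neighbour is sulfur restores a measurable reading, with an at least 1.8-fold lower number from compound 2 to compound 3 (0.25 log units; that floor lies within the scatter); this is a minimum size only. Vinyl in place of phenyl on a saturated chain carbon bound to an oxygen next to a carbonyl group gives a 1.4-fold higher number from compound 1 to compound 3 (0.14 log units; within the scatter), so benzyloxy and allyloxy cannot be told apart here and phenyl is not required for a reading in the measured range. Compound 2 remains a limit of the assay and not a number, so the true size of any step from it stays unknown: the limit of > 50000 nM in this assay, at which 1 of the 3 values shown sits.

The compounds shown do not separate the effect of the oxygen from that of the group beyond it. As far as these compounds go, how an amine on this carbonyl carbon or a longer chain in place of allyl would read remains open.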